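Notes on a 4-methoxyphenyl to 4-chlorophenyl swap

The source may report more compounds than this note shows. Statements on the series, on what has been measured and on what is new or still open speak of the compounds shown alone.

Three compounds in this series have numbers in a functional assay on A549 cells (Homo sapiens) for antiproliferative activity, read by MTT assay, with a stated time of 72 h; on this read-out higher numbers stand for weaker inhibition and lower numbers for stronger inhibition. Compound 1 (`COc1ccc(N2C(=O)COc3ccc(-c4cnc(Cl)c(NS(=O)(=O)c5ccc(F)cc5)c4)cc32)cc1`) gives 30400 nM. Compound 3 (`O=C1COc2ccc(-c3cccc(NS(=O)(=O)c4ccc(F)cc4)c3)cc2N1c1ccc(Cl)cc1`) gives 31600 nM, which lies within the scatter of compound 1. Compound 2 (`COc1ncc(-c2ccc3c(c2)N(c2ccc(F)cc2)C(=O)CO3)cc1NS(=O)(=O)c1ccc(F)cc1`) gives 6500 nM, a lower number than compound 1 by more than the scatter, so compound 1 sits level with compound 3 and on the weaker side of compound 2.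

Compound 4 (`O=C1COc2ccc(-c3cnc(Cl)c(NS(=O)(=O)c4ccc(F)cc4)c3)cc2N1c1ccc(Cl)cc1`) has no number yet. It differs from compound 1 in one place: chloro in place of methoxy on an aromatic carbon. This is chloro in place of methoxy on an aromatic carbon, para to a large group, turning the 4-methoxyphenyl into 4-chlorophenyl.

Within the data shown here, no measured pair isolates this change, so its size in this assay can only be judged indirectly. Compound 3 also carries the 4-chlorophenyl group and gives 31600 nM, which offers no sign that this group brings stronger inhibition. Compound 2 differs from compound 1 in more than one place, so its lower number cannot be assigned to any single change. No step beyond the scatter is expected, and a small move towards a lower number is the likelier direction. The estimated step, a 1.2-fold lower number from compound 1 to compound 4 (0.08 log units; within the scatter), is expected to stay within the scatter. For compound 4 the expected value is 25000 nM, with an estimated range from 10000 nM to 60000 nM.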

Compound 4, half-maximal inhibitory concentration: 21600 nM
Compound 4: the middle estimate sits 1.2-fold (0.06 log units) above what was measured, and the stated range covers the measured number.
By their numbers in this assay, from the lowest: compound 2; then compounds 4, 1 and 3 (each within the scatter of the next).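

Among these compounds, the pair compound 1 and compound 4 gives the first direct reading of this change in this assay, and chloro in place of methoxy on the aromatic carbon is a 1.4-fold lower number from compound 1 to compound 4 (0.15 log units; within the scatter) on the shared core. The number therefore does not separate the 4-methoxyphenyl from the 4-chlorophenyl group at this position. In counted terms, one heavy atom enters for two and one hydrogen-bond acceptor leaves, and the step still stays within the usual scatter of repeated measurements. No measured evidence in hand gives a reason for this result.

The compounds shown leave open whether any group at this position can move the number beyond the scatter, for example an amine, a carboxylic acid or a longer alkoxy chain in place of the chloro. They also leave open whether the same change would give a step of similar size on a core other than that of compound 1.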